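A few compounds are considered here, and "the series" means these few. Any claim that something is new, unique, unknown or untested is made for them only; others in the source may bear on it.

Compound 1 `COC(=O)C[C@H](NC(=O)OC(C)(C)C)C(=O)N(Cc1ccccc1)C1(C(=O)NCc2ccccc2)CCN(Cc2ccccc2)CC1` was run in an ADME assay on MDCK cells (Canis lupus familiaris) for cytotoxicity, read by microscopy, with a stated time of 72 h; on this read-out higher numbers stand for lower toxicity in this test and lower numbers for higher toxicity in this test. Compound 1 gives > 100000 nM, which is a limit of the assay rather than a number, placing compound 1 at the limit of > 100000 nM in this assay, at which 1 of the 2 values shown sits. Compound 2 `COC(=O)C[C@H](NC(=O)OC(C)(C)C)C(=O)N(Cc1ccc(F)cc1)C1(C(=O)NCS(=O)(=O)c2ccc(C)cc2)CCN(Cc2ccccc2)CC1` gives 4000 nM in this assay, and no single-change step connects compound 2 to compound 1, so only the two values themselves are shown. Compound 3 `COC(=O)C[C@H](NC(=O)OC(C)(C)C)C(=O)N(Cc1cccc(F)c1)C1(C(=O)NCc2ccccc2)CCN(Cc2ccccc2)CC1` differs from compound 1 by fluoro in place of hydrogen on an aromatic carbon, the entering group being a single heavy atom. For compound 3 a step of a number no higher from compound 1 to compound 3 (the limit leaves the size open) within the scatter is expected, most likely reported again as a limit. For compound 3 the estimate is 100000 nM, in the range 30000 nM to 300000 nM.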

Compound 3, minimum cytotoxic concentration: 47000 nM
Compound 3: middle estimate off by 2.1-fold (0.33 log units), on the high side, within the range that was stated.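

In this assay, a single heavy atom at this position is enough to move the read-out: the change from benzyl to 3-fluorobenzyl gives an at least 2.1-fold lower number from compound 1 to compound 3 (0.32 log units; beyond the scatter), toward higher toxicity in this test. For the compounds shown here, compound 3 thereby gives the first measured number on the core of compound 1. For compound 1 the value > 100000 nM is a limit of the assay, and the full size of the step stays open: the limit of > 100000 nM in this assay, at which 1 of the 3 values shown sits.

Open, on these data alone, is whether chloro, methoxy or a nitrile in place of the fluoro would give a similar step. Also open, as far as these compounds go, is whether the step carries over to other cores.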